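A few compounds are considered here, and "the series" means these few. Any claim that something is new, unique, unknown or untested is made for them only; others in the source may bear on it.

Compound 1 `CCC1=C(O)c2c(oc(-c3ccc(OC)cc3)cc2=O)C(CC)(CC)C1=O`: 0.68 uM
Compound 2 `CCC1=C(O)c2c(oc(-c3ccc(OC(F)(F)F)cc3)cc2=O)C(CC)(CC)C1=O`: 9.95 uM
Compound 3 `CCC1=C(O)c2c(oc(-c3cccc(OC)c3)cc2=O)C(CC)(CC)C1=O`: 1.22 uM

These three compounds were compared in a functional assay on KBVIN cells (Homo sapiens) for antiproliferative activity, read by sulforhodamine B assay, with a stated time of 3 days; a higher number here means that more compound is needed for the effect, a lower number that less compound is needed. Compound 2 differs from compound 1 by trifluoromethyl in place of methyl on an oxygen on an aromatic ring, and that change made a 15-fold higher number from compound 1 to compound 2 (1.17 log units; beyond the scatter). Compound 3 differs from compound 1 by 3-methoxyphenyl in place of 4-methoxyphenyl on an aromatic carbon, and that change made a 1.8-fold higher number from compound 1 to compound 3 (0.25 log units; within the scatter). Compound 4 `CCC1=C(O)c2c(oc(-c3cccc(OC(F)(F)F)c3)cc2=O)C(CC)(CC)C1=O` has not yet been measured; it differs from compound 3 by trifluoromethyl in place of methyl on an oxygen on an aromatic ring, the same change at the same place that separates compound 1 from compound 2. Within the data shown here, compound 4 is therefore expected to show a 15-fold higher number from compound 3 to compound 4 (1.17 log units; beyond the scatter), because a 15-fold higher number from compound 1 to compound 2 (1.17 log units; beyond the scatter) is the only measured instance of this change. The estimate for compound 4 is 18 uM, with a likely range from 6 uM to 50 uM.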

Compound 4, concentration for half-maximal effect: 9.95 uM
Estimate against measurement, compound 4: 1.8-fold (0.26 log units) above; measured number inside the range.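

In this assay, the change from methoxy to trifluoromethoxy gave an 8.2-fold higher number from compound 3 to compound 4 (0.91 log units; beyond the scatter). Set beside the earlier instance, the step does not differ in size: the same change on two cores in this assay, a 15-fold higher number (1.17 log units; beyond the scatter) from compound 1 to compound 2 and an 8.2-fold higher number (0.91 log units; beyond the scatter) from compound 3 to compound 4, 1.8-fold (0.25 log units) apart, within the scatter of two such steps. The change therefore carried from one core to the other in this series in both direction and size, but two cores are a narrow basis, and the pair shows neither why the number rises nor whether the step would hold on a core altered elsewhere.

The compounds shown leave open how an ethyl or a longer chain on the same oxygen would behave. They also leave open what an amine or a carboxylic acid on the aromatic ring would do to the number.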